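The source may hold more compounds than are shown below. What is called first, only, known or untested is meant among the compounds shown, and "the series" means these compounds.

Measured in a functional assay on SGC-7901 cells (Homo sapiens) for antiproliferative activity, read by MTT assay, with a stated time of 72 h; a higher number here means a weaker inhibitor, a lower number a stronger inhibitor:
- compound 1 `CCOc1ccc(-c2ccc3ncn(-c4cc(OC)c(OC)c(OC)c4)c3c2)cc1`: 2970 nM
- compound 2 `COc1cc(-n2cnc3ccc(-c4ccc(C)cc4F)cc32)cc(OC)c1OC`: 5650 nM
- compound 3 `COc1ccc(-c2ccc3ncn(-c4cc(OC)c(OC)c(OC)c4)c3c2)cc1F`: 430 nM

Compound 2 cannot be told apart from compound 1, given a 1.9-fold higher number from compound 1 to compound 2 (0.28 log units; within the scatter), and it lies far from compound 3, with a 13-fold lower number from compound 2 to compound 3 (1.12 log units; beyond the scatter). Compound 4 `COc1cc(-n2cnc3ccc(-c4ccc([N+](=O)[O-])cc4)cc32)cc(OC)c1OC` changes one group of compound 2: 4-nitrophenyl in place of 2-fluoro-4-methylphenyl on an aromatic carbon. All three measured steps fall at this same place, and compound 1 also gives a 6.9-fold lower number from compound 1 to compound 3 (0.84 log units; beyond the scatter), so swaps here have ranged from nothing detectable to large. None of them involves 4-nitrophenyl, so the direction is weakly supported. In this assay, a small move to a lower number is expected, a 2.3-fold lower number from compound 2 to compound 4 (0.35 log units; beyond the scatter). The estimate for compound 4 is 2500 nM, with an expected range of 600 nM to 8000 nM.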

Compound 4, half-maximal inhibitory concentration: 79 nM
Beside the measured number, compound 4's estimate is 32-fold (1.50 log units) above it; the measured number lies below the stated range.
By their numbers in this assay, from the lowest: compound 4; then compound 3; then compounds 1 and 2 (each within the scatter of the next).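

In this assay, 4-nitrophenyl produced the largest step yet at this aromatic carbon (a 72-fold lower number from compound 2 to compound 4 (1.85 log units; beyond the scatter)), and it also passed the previous lowest compound (a 5.4-fold lower number from compound 3 to compound 4 (0.74 log units; beyond the scatter)) and the ethoxy compound (a 38-fold lower number from compound 1 to compound 4 (1.58 log units; beyond the scatter)). This position can therefore reach lower numbers than the fluorinated and ethoxy aryl groups showed, and compound 4 stands lowest of the four. No evidence here accounts for this gain. As far as these compounds go, whether an amine or a nitrile in place of nitro would keep so low a number remains open.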